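Halogen swap on the aryl piperazine of compound 2

This account rests on a few compounds, and the source may have more. Where it says the series, first, only, none or still open, it means among the compounds named here.

Measured so far:
- compound 1 `CCCn1c(=O)[nH]c2nc(-c3ccc(S(=O)(=O)N4CCN(c5ccccc5Br)CC4)cc3)[nH]c2c1=O`: 0.137 nM
- compound 2 `CCCn1c(=O)[nH]c2nc(-c3ccc(S(=O)(=O)N4CCN(c5ccc(F)cc5)CC4)cc3)[nH]c2c1=O`: 0.644 nM

Both compounds share one core and differ only in the aromatic group on the amine nitrogen in the ring. In an assay on CHO cells for displacement of a labelled ligand from adenosine receptor A2b (Homo sapiens), read by scintillation counting, with a stated time of 75 min, in the presence of a further agent that is not named here (on this read-out lower numbers stand for stronger inhibition and higher numbers for weaker inhibition), compound 2 gives 0.644 nM, the higher of the two numbers measured, so the weaker binder of the pair. Going by the values given here, its nearest neighbour is compound 1, and the only step available, a 4.7-fold higher number from compound 1 to compound 2 (0.67 log units; beyond the scatter), shows that 4-fluorophenyl in place of 2-bromophenyl weakened binding by a modest but real amount.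

Compound 3 `CCCn1c(=O)[nH]c2nc(-c3ccc(S(=O)(=O)N4CCN(c5cccc(Cl)c5)CC4)cc3)[nH]c2c1=O` is not yet measured. It differs from compound 2 as follows: 3-chlorophenyl in place of 4-fluorophenyl on an amine nitrogen in a ring. Among the compounds with values here, the new group, 3-chlorophenyl, again places a heavier halogen on the phenyl, as in compound 1, but elsewhere on the ring than either bromine or fluorine, so the single step known only partly bears on it. A step of about the same size as a 4.7-fold higher number from compound 1 to compound 2 (0.67 log units; beyond the scatter), but in the opposite direction, is the most that can be expected, and a smaller one is as likely. The estimate for compound 3 in this assay is therefore 0.3 nM, with a range from 0.1 nM to 1 nM, which means an expected step of a 2.1-fold lower number from compound 2 to compound 3 (0.33 log units; beyond the scatter).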

Compound 3, inhibition constant: 0.342 nM
Beside the measured number, compound 3's estimate is 1.1-fold (0.06 log units) below it, and the stated range covers the measured number.
By their numbers in this assay, from the lowest: compound 1; then compounds 3 and 2 (each within the scatter of the next).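

In this assay, the step of a 1.9-fold lower number from compound 2 to compound 3 (0.27 log units; within the scatter) stays within the usual scatter, so compounds 2 and 3 cannot be told apart, even though 3-chlorophenyl differs from 4-fluorophenyl in both the halogen and where it sits on the phenyl. The step of a 2.5-fold higher number from compound 1 to compound 3 (0.40 log units; beyond the scatter) lies beyond the scatter, though it is modest, so compound 1, with its 2-bromophenyl, now stands apart from both other compounds as the strongest binder of the three, and a chlorine on the phenyl does not by itself match it. Nothing available gives a reason for these differences.

Because each of the three groups changes the halogen and its place on the phenyl together, these compounds cannot show which of the two matters, or whether the gap to compound 1 comes from the bromine or from its place on the ring. A 2-chlorophenyl, a 3-bromophenyl or a plain phenyl with no halogen at the same ring nitrogen would separate those questions, and a methoxy group on the phenyl would show whether a halogen is needed at all.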